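Metabolic Stability in Human Liver Microsomes: Compound 3 to Compound 4

A few compounds are considered here, and "the series" means these few. Any claim that something is new, unique, unknown or untested is made for them only; others in the source may bear on it.

Compound 1 `COc1ccc(-c2c(C)sc3c(N4CC[C@@H](NC(C)=O)C4)nc(C)nc23)cc1OC` gives > 95%, a limit of the assay rather than a number.
Compound 2 `CC(=O)N[C@@H]1CCN(c2cc(C)nn3c(-c4ccc(C#N)cc4)c(C)nc23)C1` gives > 95%, also a limit.
Compound 3 `COc1ccc(-c2c(C)nc3c(N4CC[C@@H](NC(=O)OCc5ccccc5)C4)cc(C)nn23)cc1OC` gives > 95%, again a limit.

In an ADME assay on microsomes from liver (Homo sapiens) for metabolic stability, read by LC-MS, with NADPH named in the record, with a stated time of 60 min, tested at 1 uM, in the absence of a further agent (on this read-out lower numbers stand for a less stable compound and higher numbers for a more stable compound), all three measured compounds sit at the limit of > 95% in this assay, at which 3 of the 3 values shown sit, so compound 3 cannot be set apart from the other two; its value is a limit, not a number. Compound 4 `COc1ccc(-c2c(C)nc3c(N4CCCC4)cc(C)nn23)cc1OC` differs from compound 3 by hydrogen in place of (benzyloxycarbonyl)amino on a saturated ring carbon. Among the compounds with values here, no measured step of this kind exists among the three compounds, and none of them falls below the limit. Compound 4 is therefore expected to remain close to the limit, with a step of a number at least 3 percentage points lower from compound 3 to compound 4 (that floor lies within the scatter) expected to lie within the scatter. The estimate for compound 4 is 92%, from 75% to 99%.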

Compound 4, percent of the compound remaining: > 95%
Compound 4 ended at the assay's limit; the forecaster's own chance of this, stated with the estimate: 60%; middle value at least 3 percentage points away from the limit.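

Compound 3 and compound 4 both give a limit rather than a number, so no step between them can be read: the limit of > 95% in this assay, at which 4 of the 4 values shown sit.

The compounds shown leave open whether hydrogen in place of (benzyloxycarbonyl)amino on a saturated ring carbon changes the percent remaining at all.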